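From tert-Butyl to Methoxy on a Shared Core

A few compounds are considered here, and "the series" means these few. Any claim that something is new, unique, unknown or untested is made for them only; others in the source may bear on it.

Three compounds share one core and differ only in the group on one aromatic carbon. Compound 1 `Cc1c(C(=O)Nc2ccc(Oc3ncnc4[nH]cc(-c5ccccc5)c34)c(F)c2)c(=O)c2cc(Br)ccc2n1C` carries a bromo there and, in an assay on isolated protein for inhibition of tyrosine-protein kinase receptor UFO (Homo sapiens), read by FRET and Z'-LYTE, with a stated time of 1.5 h (on this read-out higher numbers stand for weaker inhibition and lower numbers for stronger inhibition), compound 1 gives 3120 nM. Compound 2 `Cc1c(C(=O)Nc2ccc(Oc3ncnc4[nH]cc(-c5ccccc5)c34)c(F)c2)c(=O)c2cc(C3CC3)ccc2n1C` carries a cyclopropyl, and in this assay compound 2 gives 230 nM. Compound 3 `Cc1c(C(=O)Nc2ccc(Oc3ncnc4[nH]cc(-c5ccccc5)c34)c(F)c2)c(=O)c2cc(C(C)(C)C)ccc2n1C` carries a tert-butyl, and in this assay compound 3 gives 42 nM, the lowest of the three numbers, with its steps to both others beyond the scatter: a 74-fold lower number from compound 1 to compound 3 (1.87 log units; beyond the scatter) and a 5.5-fold lower number from compound 2 to compound 3 (0.74 log units; beyond the scatter), while a 14-fold lower number from compound 1 to compound 2 (1.13 log units; beyond the scatter).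

Compound 4 `COc1ccc2c(c1)c(=O)c(C(=O)Nc1ccc(Oc3ncnc4[nH]cc(-c5ccccc5)c34)c(F)c1)c(C)n2C` is the next step from compound 3: methoxy in place of tert-butyl on an aromatic carbon. Among the measured compounds shown here, no measured step involves a methoxy, so none of the three maps directly onto this change. What they show is that every exchange at this position moved the number beyond the scatter, and that compound 1 and compound 2, the two without tert-butyl, both gave higher numbers than compound 3. Compound 4 is therefore expected to give a higher number than compound 3. The expected step is a 19-fold higher number from compound 3 to compound 4 (1.28 log units; beyond the scatter) in this assay. The estimate for compound 4 in this assay is 800 nM, with a range from 150 nM to 4000 nM.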

Compound 4, half-maximal inhibitory concentration: 99 nM
Compound 4: middle estimate off by 8.1-fold (0.91 log units), on the high side, outside the stated range (below it).
By their numbers in this assay, from the lowest: compound 3; then compound 4; then compound 2; then compound 1.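

In this assay, the tert-butyl gives way to a methoxy, which has fewer heavy atoms and brings a hydrogen-bond acceptor, at only a modest cost: a 2.4-fold higher number from compound 3 to compound 4 (0.37 log units; beyond the scatter). Compound 4 also stands clear of the two remaining compounds, with a 2.3-fold lower number from compound 2 to compound 4 (0.37 log units; beyond the scatter) and a 32-fold lower number from compound 1 to compound 4 (1.50 log units; beyond the scatter), so the position does not simply divide the tert-butyl from every other group; the four compounds instead spread out, with compound 3 lowest and compound 1 highest. No measurement available here accounts for this order.

Going by these compounds, only the methoxy speaks for groups attached through oxygen, so it remains open whether an ethoxy, a hydroxyl or a trifluoromethoxy on the same aromatic carbon would fall near compound 4 or move well away from it. On these data alone, it also remains open whether the number of compound 3 marks the low end at this position, or whether a trifluoromethyl, a longer chain such as n-butyl, or an amine such as dimethylamino would give a number lower than any of these four.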